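This account rests on a few compounds, and the source may have more. Where it says the series, first, only, none or still open, it means among the compounds named here.

Measured so far in a functional assay on NCI-H460 cells (Homo sapiens) for inhibition, read by MTT assay, with a stated time of 72 h; on this read-out lower numbers stand for stronger inhibition and higher numbers for weaker inhibition:
- compound 1 `COc1cc(NC(C)CCCNC(=O)NNC(=O)Nc2ccc(Cl)cc2)c2ncccc2c1`: 63000 nM
- compound 2 `COc1cc(NC(C)CCCNC(=O)Nc2cccc(O)c2)c2ncccc2c1`: 25000 nM

Going by the values given here, of these two numbers, the one for compound 2, 25000 nM, is the lower, so compound 2 is the stronger inhibitor here, though neither number is small. The next compound to be tested is compound 3 `COc1cc(NC(C)CCCNC(=O)Nc2ccc(C(F)(F)F)cc2)c2ncccc2c1`. It keeps the shared core and chain of compound 2 and differs in one place: 4-(trifluoromethyl)phenyl in place of 3-hydroxyphenyl on an amide-type nitrogen. In words, 4-(trifluoromethyl)phenyl stands in place of 3-hydroxyphenyl on an amide-type nitrogen.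

Among the compounds with values here, only one measured step touches this nitrogen: a 2.5-fold lower number from compound 1 to compound 2 (0.40 log units; beyond the scatter). That change swapped a larger group for 3-hydroxyphenyl, and the number moved only modestly. Within the data shown here, no measured step compares one substituted phenyl with another, so the data set no direction for this change. In this assay, no step beyond the scatter is therefore expected, and a step of the modest size seen from compound 1 to compound 2 would be the likely upper limit in either direction. The expected step is a 1.3-fold lower number from compound 2 to compound 3 (0.10 log units; within the scatter). For compound 3 the estimated value is 20000 nM, with an expected range of 8000 nM to 55000 nM.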

Compound 3, half-maximal inhibitory concentration: 24000 nM
For compound 3 the middle estimate is 1.2-fold (0.08 log units) below the measured one; the measured number falls inside the stated range.
By their numbers in this assay, from the lowest: compounds 3 and 2 (each within the scatter of the next); then compound 1.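

In this assay, going by these compounds alone, this is the first comparison of one substituted phenyl with another on this amide-type nitrogen, and it gives a 1.0-fold lower number from compound 2 to compound 3 (0.02 log units; within the scatter). The two groups therefore cannot be told apart here, even though 4-(trifluoromethyl)phenyl has more heavy atoms, carries fluorine and has no hydrogen-bond donor or acceptor, whereas 3-hydroxyphenyl has one of each. Replacing ((4-chlorophenyl)carbamoyl)amino with 4-(trifluoromethyl)phenyl gives a 2.6-fold lower number from compound 1 to compound 3 (0.42 log units; beyond the scatter), a modest step, and no evidence is available on what lies behind either result.

It remains open whether any group on this nitrogen can bring the number down substantially; every step shown so far is either modest or within the scatter. An unsubstituted phenyl, a methyl group, or a phenyl ring bearing an amine or a carboxylic acid would probe this position further, while a longer chain would test the part of the structure that all three compounds share.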